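Swapping the pyrazole substituents at the pyridine ring

The compounds below may be only part of what the source reports. "The series", "measured", "known", "first", "only" and "open" are said of these compounds alone.

Measured compounds:
compound 1, `CCOc1cc(-c2cccnc2)ccc1C(N)=O`, 2200 nM
compound 2, `CC(C)Oc1cc(-c2cncc(-c3cnn(C4COC4)c3)c2)ccc1C(N)=O`, 200 nM

Two compounds have numbers in an assay on cells for inhibition of MAP kinase-interacting serine/threonine-protein kinase 1 (Homo sapiens), read by mobility shift assay, with stated times of 10 min and 60 min, in the presence of a further agent that is not named here; on this read-out higher numbers stand for weaker inhibition and lower numbers for stronger inhibition. Compound 1, `CCOc1cc(-c2cccnc2)ccc1C(N)=O`, gives 2200 nM in this assay. Compound 2, `CC(C)Oc1cc(-c2cncc(-c3cnn(C4COC4)c3)c2)ccc1C(N)=O`, gives 200 nM and so has the lower of the two numbers; the gap between compound 2 and compound 1 is well beyond the usual scatter of repeated measurements. For the measured compounds named here, no pair of measured compounds differs in a single place, so no step is available as a guide.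

Compound 3, `Cc1n[nH]c(C)c1-c1cncc(-c2ccc(C(N)=O)c(OC(C)C)c2)c1`, is not yet measured. It differs from compound 2 as follows: 3,5-dimethyl-1H-pyrazol-4-yl in place of 1-(oxetan-3-yl)-1H-pyrazol-4-yl on an aromatic carbon.

With no comparable step in hand, the account can only reason from compound 2 itself. The step from compound 2 to compound 3 in this assay is estimated to be small, a 1.5-fold higher number from compound 2 to compound 3 (0.18 log units; within the scatter), and likely within the scatter. Compound 3 is therefore expected to give about 300 nM in this assay, with a plausible range from 100 nM to 1000 nM.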

Compound 3, half-maximal inhibitory concentration: 33 nM
Beside the measured number, compound 3's estimate is 9.1-fold (0.96 log units) above it; measured number outside the range, below it.
By their numbers in this assay, from the lowest: compound 3; then compound 2; then compound 1.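

In this assay, the swap of 1-(oxetan-3-yl)-1H-pyrazol-4-yl for 3,5-dimethyl-1H-pyrazol-4-yl gives a 6.1-fold lower number from compound 2 to compound 3 (0.78 log units; beyond the scatter) at this aromatic carbon, two atoms from the ring nitrogen. For the compounds shown here, this is the first comparison that differs in one place, and it shows that the choice of pyrazole group alone, with the rest of compound 2 unchanged, can move the number beyond the usual scatter. Nothing at hand accounts for why this change lowers the number.

The compounds shown leave open which part of the change carries the step, since the four-membered ring leaves while the two methyl groups and the hydrogen-bond donor of the 1H-pyrazole enter together. Also open, going by these compounds, is how a plain 1H-pyrazol-4-yl, a 3-methyl-1H-pyrazol-4-yl or a 3,5-diethyl-1H-pyrazol-4-yl group at this position would compare with compound 3.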